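Tetrazole for oxadiazole on the biaryl arm of compound 1

A few compounds are considered here, and "the series" means these few. Any claim that something is new, unique, unknown or untested is made for them only; others in the source may bear on it.

Measured so far:
compound 1 `Cc1noc(-c2c(F)cccc2-c2ccc([C@@H](C)Nc3nccc(Cl)c3NC(=O)CC#N)cc2)n1`: 2.7 nM
compound 2 `COC(=O)c1c(Cl)cccc1-c1ccc([C@@H](C)Nc2nccc(Cl)c2NC(=O)CC#N)cc1`: 1.1 nM

Both numbers come from an assay on isolated protein for binding affinity to B1 bradykinin receptor (Oryctolagus cuniculus); on this read-out higher numbers stand for weaker inhibition and lower numbers for stronger inhibition. Compound 1 has the higher of the two numbers; compound 2 sits lower, a gap beyond the scatter. Compound 3 `C[C@@H](Nc1nccc(Cl)c1NC(=O)CC#N)c1ccc(-c2cccc(F)c2-c2nnn(C)n2)cc1` is not yet measured; it carries 2-methyl-2H-tetrazol-5-yl in place of 3-methyl-1,2,4-oxadiazol-5-yl on an aromatic carbon, that is 2-methyl-2H-tetrazol-5-yl in place of 3-methyl-1,2,4-oxadiazol-5-yl on an aromatic carbon. Going by the values given here, no step between measured compounds shows this change, so in this assay a step of a 1.1-fold higher number from compound 1 to compound 3 (0.05 log units; within the scatter) is expected, nothing beyond the scatter in either direction. Compound 3 is expected to give 3 nM in this assay, within 1 nM to 9 nM.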

Compound 3, inhibition constant: 3 nM
Estimate against measurement, compound 3: no gap at the digits printed, and the stated range covers the measured number.
By their numbers in this assay, from the lowest: compound 2; then compounds 1 and 3 (each within the scatter of the next).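

In this assay the exchange of 3-methyl-1,2,4-oxadiazol-5-yl for 2-methyl-2H-tetrazol-5-yl gives a 1.1-fold higher number from compound 1 to compound 3 (0.05 log units; within the scatter) and so leaves the number within the scatter. This aromatic carbon, ortho to a fluoro group, thus accepts a five-membered aromatic ring with 4 hetero atoms as well as one with 3, despite the added hydrogen-bond acceptor. Nothing measured here accounts for this equivalence. From the compounds shown here alone, whether a carboxylic acid or a primary amine on this carbon would hold the number remains open.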